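This account rests on a few compounds, and the source may have more. Where it says the series, first, only, none or still open, it means among the compounds named here.

- Compound 1 `O=C(OC1C=CC(n2ccc(=O)n(C(=O)c3ccccc3)c2=O)C1)c1ccccc1`: >= 250000 nM, a limit of the assay and not a number
- Compound 2 `Cc1cc(C)cc(Cn2c(=O)ccn(C3C=CC(OC(=O)c4ccccc4)C3)c2=O)c1`: 40000 nM

Within the data shown here, in an ADME assay on CCRF-CEM cells (Homo sapiens) for cytotoxicity, with a stated time of 3 days (a lower number here means that less compound is tolerated, a higher number that more compound is tolerated), compound 2 holds the only true number so far, 40000 nM. Compound 3 `O=C(OC1C=CC(n2ccc(=O)n(Cc3cc(F)cc(F)c3)c2=O)C1)c1ccccc1` has 3,5-difluorophenyl in place of 3,5-dimethylphenyl on a saturated chain carbon bound to an aromatic nitrogen. Among the measured compounds shown here, the one measured step, an at least 6.2-fold lower number from compound 1 to compound 2 (0.79 log units; beyond the scatter), also concerns the group on that aromatic nitrogen, but it replaces benzoyl, which is a different change. For the measured compounds named here, no measured step swaps these two groups, so only a small move is expected, with no clear direction: the expected step is a 1.4-fold higher number from compound 2 to compound 3 (0.14 log units; within the scatter). For compound 3 the estimate is 55000 nM, with an expected range of 20000 nM to 150000 nM.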

Compound 3, half-maximal cytotoxic concentration: 32000 nM
The estimate for compound 3 lay 1.7-fold (0.24 log units) above the measured number, within the range that was stated.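

In this assay, 3,5-difluorophenyl in place of 3,5-dimethylphenyl gives a 1.3-fold lower number from compound 2 to compound 3 (0.10 log units; within the scatter), so this assay does not separate the two groups at this position. A second benzyl group also differs clearly from benzoyl, with an at least 7.8-fold lower number from compound 1 to compound 3 (0.89 log units; beyond the scatter), so the gap from benzoyl now rests on two benzyl compounds rather than one. Compound 1 holds a limit and not a number: the limit of >= 250000 nM in this assay, at which 1 of the 3 values shown sits.

Still open, from the compounds shown here alone, is how a benzyl group carrying an amine or a carboxylic acid would compare, and the same goes for a longer chain in place of benzyl.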